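The source may report more compounds than this note shows. Statements on the series, on what has been measured and on what is new or still open speak of the compounds shown alone.

Compound 2 `O=C(Nn1c(-c2ccccc2)nc2c(-c3ccc(Cl)cc3)n[nH]c2c1=O)c1ccccc1` and compound 1 `COc1cccc(-c2nc3c(-c4ccc(Cl)cc4)n[nH]c3c(=O)n2NC(=O)c2ccccc2)c1` share one core and differ only in a methoxy group on an aromatic carbon. In a functional assay on DU-145 cells (Homo sapiens) for inhibition, read by MTT assay, with a stated time of 2 days (a lower number here means a stronger inhibitor of growth, a higher number a weaker inhibitor of growth), compound 1 gives 17900 nM, and compound 2 gives 20100 nM. The step of a 1.1-fold higher number from compound 1 to compound 2 (0.05 log units; within the scatter) is a hydrogen in place of methoxy and lies within the scatter, so compound 2 stands at the higher of the two numbers without being separable from compound 1.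

Compound 3 `COc1cccc(Cc2nc3c(-c4ccc(Cl)cc4)n[nH]c3c(=O)n2NC(=O)c2ccccc2)c1` is the next step from compound 2: 3-methoxybenzyl in place of phenyl on an aromatic carbon. Going by the values given here, of the measured steps only the one from compound 1 to compound 2 bears on it, and only in part, since it shows that adding or removing a methoxy on this aromatic ring moves the number by a 1.1-fold higher number from compound 1 to compound 2 (0.05 log units; within the scatter). Among the compounds with values here, the added methylene has no measured counterpart here. Compound 3 is therefore expected to stay close to compound 2, with a step of a 1.1-fold lower number from compound 2 to compound 3 (0.05 log units; within the scatter) in this assay, not beyond the scatter. The estimate for compound 3 is 18000 nM, within a range from 6000 nM to 55000 nM.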

Compound 3, concentration for 50% growth inhibition: 44900 nM
Compound 3: the middle estimate sits 2.5-fold (0.40 log units) below what was measured; the range from low to high includes it.
By their numbers in this assay, from the lowest: compounds 1 and 2 (each within the scatter of the next); then compound 3.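

In this assay, this position, on an aromatic carbon between two ring nitrogen atoms, responds to a change in how the aromatic ring is attached, whereas the methoxy group alone gave only a 1.1-fold higher number from compound 1 to compound 2 (0.05 log units; within the scatter), within the scatter. With the methoxy kept in place, 3-methoxybenzyl in place of 3-methoxyphenyl gives a 2.5-fold higher number from compound 1 to compound 3 (0.40 log units; beyond the scatter), and the full change from phenyl to 3-methoxybenzyl gives a 2.2-fold higher number from compound 2 to compound 3 (0.35 log units; beyond the scatter); both steps are modest but beyond the scatter, and they leave compound 3 as the weakest inhibitor of growth of the three. No measurement given here explains this loss.

The compounds shown leave open how a plain benzyl group would read at this position, and so whether the methoxy matters once the methylene is present. They also leave open whether a longer chain such as 2-phenylethyl would extend the step seen with 3-methoxybenzyl, and how an amine or a carboxylic acid on the aromatic ring would compare with the methoxy group.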